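A few compounds are considered here, and "the series" means these few. Any claim that something is new, unique, unknown or untested is made for them only; others in the source may bear on it.

Measured so far:

Compound 1, `COc1ccc(S(C)(=O)=O)c(NCC2=NCCN2)c1`: in an assay for binding affinity to Alpha-1B adrenergic receptor (Homo sapiens), read by radioligand binding (on this read-out lower numbers stand for stronger inhibition and higher numbers for weaker inhibition), compound 1 gives 4570 nM.
Compound 2, `CSc1ccc(C(F)(F)F)cc1NCC1=NCCN1`: in this assay compound 2 gives 2040 nM.

Within the data shown here, of the two numbers known, compound 2 has the lower one, and the gap to compound 1 lies beyond the usual scatter of repeated measurements, so compound 2 is the stronger binder of the pair. The next compound, compound 3, `CS(=O)(=O)c1ccc(C(F)(F)F)cc1NCC1=NCCN1`, is not yet measured. It differs from compound 2 in one place: methylsulfonyl in place of methylsulfanyl on an aromatic carbon. Among the measured compounds shown here, no pair of measured compounds shows this same single change, so the size of the step cannot be read off from the data at hand. For the measured compounds named here, the only compound here that carries a methylsulfonyl group, compound 1, gives a higher number than compound 2, but it also differs from compound 2 elsewhere, so its value can only hint at the direction. A modest move toward weaker binding, of a size just beyond the scatter, is expected. The estimated step is a 2.2-fold higher number from compound 2 to compound 3 (0.34 log units; beyond the scatter). For compound 3 the expected result in this assay is 4500 nM, with a likely range from 1500 nM to 13000 nM.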

Compound 3, inhibition constant: < 10000 nM
Compound 3 was reported as a limit (the forecaster's own chance of this, stated with the estimate: 10%); the middle value lies beyond the limit too.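

In this assay compound 3 gives < 10000 nM, which is a limit and not a number. The steps from compound 1 and from compound 2 to compound 3 therefore cannot be read. On these data alone, whether methylsulfonyl in place of methylsulfanyl, or trifluoromethyl in place of methoxy, raises the number, lowers it or leaves it unchanged stays open.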